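The source may report more compounds than this note shows. Statements on the series, on what has been measured and on what is new or still open speak of the compounds shown alone.

Values so far in a functional assay on the whole organism for inhibition, with Rattus norvegicus as the target, read by paw edema, with stated times of 1 h and 3 h; on this read-out lower numbers stand for an effect already at smaller amounts and higher numbers for an effect only at larger amounts of compound
- compound 1 `C/C(=N\OCC(=O)OC(C)C)c1ccc(Cl)cc1` gives 50 mg/kg
- compound 2 `CC(=O)OCCO/N=C(\C)c1ccc(Cl)cc1` gives 43 mg/kg

For the measured compounds named here, compound 2 holds one of only two numbers and lies within the scatter of compound 1. The next compound is compound 3 `COC(=O)OCCO/N=C(\C)c1ccc(Cl)cc1`, which has methoxy in place of methyl on a carbonyl carbon, so that acetoxymethyl becomes ((methoxycarbonyl)oxy)methyl. Going by the values given here, no measured step covers this exact change, and only one step is available as a guide for size. No shift beyond the scatter is expected because a 1.2-fold lower number from compound 1 to compound 2 (0.07 log units; within the scatter) stayed small, although that step is a different change and the evidence is thin. The estimated step is a 1.0-fold higher number from compound 2 to compound 3 (0.02 log units; within the scatter), with no clear direction expected. For compound 3 the expected value in this assay is 45 mg/kg, with an estimated range of 25 mg/kg to 80 mg/kg.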

Compound 3, dose for half-maximal effect: 33 mg/kg
Compound 3: the middle estimate sits 1.4-fold (0.13 log units) above what was measured; low and high end bracket the measured number.
By their numbers in this assay, from the lowest: compounds 3, 2 and 1 (each within the scatter of the next).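

On a carbonyl carbon, methoxy in place of methyl in this assay gives a 1.3-fold lower number from compound 2 to compound 3 (0.11 log units; within the scatter) and so adds an oxygen and a hydrogen-bond acceptor at this position with no shift that stands clear of the scatter. ((Methoxycarbonyl)oxy)methyl in place of isopropoxycarbonyl on a saturated chain carbon bound to an oxygen gives a 1.5-fold lower number from compound 1 to compound 3 (0.18 log units; within the scatter) and is also no separable change, so all three side-chain ends shown remain within the scatter of one another. No measurement offered here bears on the reason for these values.

From the compounds shown here alone, whether an amine on the same carbonyl carbon would move the number beyond the scatter remains open. The same question holds for a longer chain in place of methoxy, and for a free carboxylic acid in place of the ester end.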